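Cytotoxicity series on the shared core: the fluorophenyl step

This account rests on a few compounds, and the source may have more. Where it says the series, first, only, none or still open, it means among the compounds named here.

Two compounds of the series have numbers in an ADME assay on HEK293 cells (Homo sapiens) for cytotoxicity, read by sulforhodamine B assay, with a stated time of 48 h, tested at 10 uM; on this read-out lower numbers stand for less inhibition and higher numbers for more inhibition at the one concentration tested (going by the name of the read-out). Compound 1 `CCCCCCCCc1cn(C(c2ccccc2)c2cc3cc(Br)ccc3nc2OC)nn1` gives 14.6%, and compound 2 `COc1nc2ccc(Br)cc2cc1C(c1ccccc1)n1cc(CCCO)nn1` gives 27.4%. Among the measured compounds shown here, compound 2 stands highest of the two, its nearest neighbour being compound 1, and the only step measured so far, a number 12.8 percentage points higher from compound 1 to compound 2 (beyond the scatter), lies beyond the scatter and is modest in size.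

Compound 3 `COc1nc2ccc(Br)cc2cc1C(c1ccccc1)n1cc(-c2ccc(F)cc2)nn1` is not yet measured in this assay. Its change from compound 2 is 4-fluorophenyl in place of 3-hydroxypropyl on an aromatic carbon. For the measured compounds named here, no measured step concerns this change: the one step in hand exchanges a hydroxy for a pentyl on a saturated chain carbon, while here an aromatic group replaces the whole 3-hydroxypropyl chain. Going by the values given here, that step is the only guide to the spread of numbers this series shows, and it is modest. The expectation is therefore a number for compound 3 near the two known values, with no step beyond the scatter predicted, a number 5.4 percentage points lower from compound 2 to compound 3 (within the scatter). Compound 3 is estimated at 22%, with a range from 5% to 42%.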

Compound 3, a percentage reported as inhibition, at one concentration (the size of the read-out at that concentration, not a potency): 4.04%
The estimate for compound 3 lay 18 percentage points above the measured number, outside the stated range (below it).
By their numbers in this assay, from the lowest: compound 3; then compound 1; then compound 2.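

At this position, on an aromatic carbon of a five-membered aromatic ring with 3 nitrogen, this assay now has an aromatic group to set against two chains: 4-fluorophenyl in place of 3-hydroxypropyl gives a number 23.4 percentage points lower from compound 2 to compound 3 (beyond the scatter), and 4-fluorophenyl in place of octyl gives a number 10.6 percentage points lower from compound 1 to compound 3 (beyond the scatter). The earlier pair held only open chains here, so it could not show that one six-membered aromatic ring of carbon only would give the lowest number of the three, below both the chain with a hydrogen-bond donor and the chain without one. No measured evidence on the cause of these steps accompanies the numbers.

With only one aromatic group at this position, the compounds shown leave open whether the lower number goes with the ring itself or with its fluorine, a question that an unsubstituted phenyl in the same place would address. Going by these compounds, how an amine or a carboxylic acid in place of 3-hydroxypropyl would stand against these three also remains open.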